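The source may hold more compounds than are shown below. What is called first, only, known or untested is meant among the compounds shown, and "the series" means these compounds.

Among the compounds with values here, compound 2 `C=CCn1c(=O)/c(=C\c2ccccc2OC)[nH]c(=O)/c1=C\c1ccccc1OC` gives 21500 nM in a functional assay on NCI-H1975 cells (Homo sapiens) for cytotoxicity, read by CCK-8 assay, with a stated time of 72 h (a lower number here means a stronger inhibitor, a higher number a weaker inhibitor), the highest of the two numbers measured so far; its nearest neighbour is compound 1 `C=CCn1c(=O)/c(=C\c2ccccc2Cl)[nH]c(=O)/c1=C\c1ccccc1OC`, which gives 9200 nM. Compound 3 `C=CCn1c(=O)/c(=C\c2ccccc2C(F)(F)F)[nH]c(=O)/c1=C\c1ccccc1OC` differs from compound 2 by trifluoromethyl in place of methoxy on an aromatic carbon. Within the data shown here, the only step that touches this position, a 2.3-fold higher number from compound 1 to compound 2 (0.37 log units; beyond the scatter), shows that swapping the group at this aromatic carbon moves the number modestly. Compound 3 is therefore expected to lie close to compound 2, with a modest lowering estimated as a 1.7-fold lower number from compound 2 to compound 3 (0.22 log units; within the scatter). The value expected for compound 3 is 13000 nM, within a range from 5000 nM to 32000 nM.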

Compound 3, half-maximal inhibitory concentration: 14500 nM
Compound 3: the middle estimate sits 1.1-fold (0.05 log units) below what was measured; low and high end bracket the measured number.
By their numbers in this assay, from the lowest: compounds 1, 3 and 2 (each within the scatter of the next, the first and the last beyond it).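

Trifluoromethyl, which brings more heavy atoms than methoxy, cannot be told apart at this aromatic carbon from methoxy (a 1.5-fold lower number from compound 2 to compound 3 (0.17 log units; within the scatter)) or from chloro (a 1.6-fold higher number from compound 1 to compound 3 (0.20 log units; within the scatter)). The modest gap between chloro and methoxy therefore now has a third group lying within the scatter of both ends, so this position has so far tolerated quite different groups with little movement. Nothing available explains why these groups read so similarly.

From the compounds shown here alone, it remains open whether an amine, a carboxylic acid or a longer chain at this carbon would move the number further. Going by these compounds, the effect of changing the methoxy on the other aromatic ring also remains open.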